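The source may report more compounds than this note shows. Statements on the series, on what has been measured and on what is new or still open speak of the compounds shown alone.

Three compounds built on a shared core have been examined in a functional assay on MCF7 cells (Homo sapiens) for inhibition, read by MTT assay, with a stated time of 72 h; a higher number here means a weaker inhibitor, a lower number a stronger inhibitor. Compound 1, `COc1cccc(NC(=O)C2CCN(C/C=C/c3ccccc3)CC2)c1`, gives 42700 nM. Compound 2, `O=C(Nc1cccc(C(F)(F)F)c1)C1CCN(C/C=C/c2ccccc2)CC1`, gives 16100 nM, and compound 3, `O=C(Nc1cc(-c2cccc(Br)c2)on1)C1CCN(C/C=C/c2ccccc2)CC1`, gives 4870 nM. Among these three numbers compound 1 stands highest: compound 2 is its nearest neighbour and compound 3 lies furthest from it. Among the compounds with values here, the single step between compounds that differ in one place is a 2.7-fold lower number from compound 1 to compound 2 (0.42 log units; beyond the scatter), where the only alteration is trifluoromethyl in place of methoxy on an aromatic carbon.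

Compound 4, `O=C(NCc1ccccc1)C1CCN(C/C=C/c2ccccc2)CC1`, has not yet been measured. It differs from compound 1 in this way: benzyl in place of 3-methoxyphenyl on an amide-type nitrogen. Within the data shown here, no measured step exchanges the whole group on the amide-type nitrogen in this manner, so the step from compound 1 to compound 2, which was modest, bears on it only loosely, and the values of compound 1 and compound 3 show that a larger change of that group went with a lower number. On this thin basis compound 4 is expected to give 30000 nM, with a range from 10000 nM to 90000 nM. The expected step is estimated as a 1.4-fold lower number from compound 1 to compound 4 (0.15 log units; within the scatter).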

Compound 4, half-maximal inhibitory concentration: > 100000 nM
Compound 4: a limit, no number; the forecaster's own chance of this, stated with the estimate: 15%; at least 3.3-fold (0.52 log units) between middle value and limit.
By their numbers in this assay, from the lowest: compound 3; then compound 2; then compound 1. At a limit, above all of these: compound 4.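

For compound 4 the reading in this assay is > 100000 nM, a limit of the assay and not a number, and it is the only such reading among these compounds: the limit of > 100000 nM in this assay, at which 1 of the 4 values shown sits.

Exchanging the whole group on the amide-type nitrogen gives an at least 2.3-fold higher number from compound 1 to compound 4 (0.36 log units; beyond the scatter), so a change at this place can raise the number as well as lower it, which compound 2 and compound 3 alone did not show. Both benzyl and 3-methoxyphenyl carry one six-membered aromatic ring of carbon only, so the presence of that ring on its own did not preserve the value of compound 1.

The change removes the oxygen of the methoxy group and also alters how the ring is attached to the amide-type nitrogen, and the compounds shown do not separate these two differences. As far as these compounds go, an unsubstituted phenyl group or a 3-methoxybenzyl group on that nitrogen would bear on this directly, and how either would read in this assay remains open.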